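The compounds below may be only part of what the source reports. "The series", "measured", "known", "first", "only" and "open" are said of these compounds alone.

Measured so far:
- compound 1 `Cn1c2cnc1OCCCCCCCCOc1cc(F)ccc1-2`: 70000 nM
- compound 2 `Cn1c2cnc1OCCCCCCCCOc1cc3ccccc3cc1-2`: 24000 nM
- compound 3 `CCCCOc1ncc(-c2ccccc2OC)n1C`: "not determined" (no result reported)

All three compounds were put through a functional assay on U-373MG ATCC cells (Homo sapiens) for inhibition, read by colorimetric assay and MTT assay, with a stated time of 72 h; on this read-out higher numbers stand for weaker inhibition and lower numbers for stronger inhibition. There, compound 1 gives 70000 nM and compound 2 gives 24000 nM. The number of compound 2 is the lower of the two, so compound 2 inhibits more strongly. Compound 3 has the entry "not determined" (no result reported), which means it has no number to serve as a starting point.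

The next compound to be tested is compound 4 `COc1ccccc1-c1cnc(OC)n1C`. The change is hydrogen in place of propyl on a saturated chain carbon bound to an oxygen on an aromatic ring, which turns butoxy into methoxy.

Within the data shown here, no measured step anchors this change in this assay. A modest step towards weaker inhibition is the expectation, though this is a judgement and not a measured trend. Among the measured compounds shown here, the only numbers to lean on are those of compound 1 at 70000 nM and compound 2 at 24000 nM, both high on this scale.

For compound 4 the expected value is 80000 nM, with an estimated range of 25000 nM to 250000 nM.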

Compound 4, half-maximal inhibitory concentration: > 100000 nM
Compound 4: a limit, no number (the forecaster's own chance of this, stated with the estimate: 50%); middle value at least 1.2-fold (0.09 log units) from the limit.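

In this assay, among these compounds, compound 3 has no number to start from, so no step to compound 4 can be read. Compound 4 gives > 100000 nM, which is a limit and not a number. The compounds shown leave open how far butoxy to methoxy shifts inhibition in this assay.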